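Phenyl in place of pyridin-2-yl on the amide carbonyl

The compounds below may be only part of what the source reports. "The series", "measured", "known", "first", "only" and "open" are said of these compounds alone.

Measured so far in a functional assay on U-251 cells (Homo sapiens) for antiproliferative activity, read by MTT assay, with a stated time of 72 h; on this read-out higher numbers stand for weaker inhibition and lower numbers for stronger inhibition:
compound 1 `O=C(Nc1ccc(Cl)c(-c2nnc3c(Cl)cccn23)c1)c1ccccn1`: 79000 nM
compound 2 `CS(=O)(=O)c1ccc(C(=O)Nc2ccc(Cl)c(-c3nnc4c(Cl)cccn34)c2)cc1`: > 100000 nM, a limit of the assay rather than a number

Among the measured compounds shown here, compound 1 carries the only real number in this assay; the other measured compound sits at the limit (the limit of > 100000 nM in this assay, at which 1 of the 2 values shown sits). Compound 3 `O=C(Nc1ccc(Cl)c(-c2nnc3c(Cl)cccn23)c1)c1ccccc1` differs from compound 1 in one place (phenyl in place of pyridin-2-yl on a carbonyl carbon). For the measured compounds named here, the one measured step at this same carbonyl, an at least 1.2-fold higher number from compound 1 to compound 2 (0.10 log units; that floor lies within the scatter), has a floor inside the scatter, so a step beyond the scatter is not expected here. Compound 3 is estimated to give 79000 nM (30000 nM to 200000 nM). The expected step is no change at the digits printed from compound 1 to compound 3 (within the scatter).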

Compound 3, half-maximal inhibitory concentration: 73500 nM
The estimate for compound 3 lay 1.1-fold (0.03 log units) above the measured number; the range from low to high includes it.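

In this assay, the nitrogen of pyridin-2-yl proves not to be needed at this carbonyl, since phenyl in its place gives a 1.1-fold lower number from compound 1 to compound 3 (0.03 log units; within the scatter). Hydrogen in place of methylsulfonyl on the aromatic carbon gives an at least 1.3-fold lower number from compound 2 to compound 3 (0.13 log units; that floor lies within the scatter), so the size of this change stays unknown. Compound 2 has only a limit of the assay, not a number: the limit of > 100000 nM in this assay, at which 1 of the 3 values shown sits.

Still open, going by these compounds, is whether an amine or a carboxylic acid on the phenyl of compound 3 would shift the number beyond the scatter.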